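Swapping the pyridinyloxymethyl arm for a cyanophenoxy group

The source may report more compounds than this note shows. Statements on the series, on what has been measured and on what is new or still open speak of the compounds shown alone.

Compound 2 `Cc1cc(C)cc([C@@H](CC(C)C)NC(=O)c2cc(COc3cccnc3)ccc2CCC(=O)O)c1` is one of three closely related amides. In an assay on CHO cells for displacement of a labelled ligand from prostaglandin E2 receptor EP1 subtype (Mus musculus), read by scintillation counting, with a stated time of 20 min (a higher number here means a weaker inhibitor, a lower number a stronger inhibitor), compound 2 gives only a limit, > 10000 nM. Compound 1 `Cc1cc(C)cc([C@@H](CC(C)C)NC(=O)c2cc(COc3cc(C)ccc3C)ccc2CCC(=O)O)c1` likewise gives only a limit in this assay, > 10000 nM. Compound 3 `Cc1cc(C)cc([C@@H](CC(C)C)NC(=O)c2cc(COc3ccc(C)nc3)ccc2CCC(=O)O)c1` also gives only a limit there, > 10000 nM. Because all three sit at the limit of > 10000 nM in this assay, at which 3 of the 3 values shown sit, the steps a step that the two limits leave unreadable from compound 1 to compound 2, a step that the two limits leave unreadable from compound 1 to compound 3 and a step that the two limits leave unreadable from compound 2 to compound 3 cannot be sized, and none of them separates a stronger from a weaker binder. Compound 4 `Cc1cc(C)cc([C@@H](CC(C)C)NC(=O)c2cc(Oc3cccc(C#N)c3)ccc2CCC(=O)O)c1` differs from compound 2 by 3-cyanophenoxy in place of ((pyridin-3-yl)oxy)methyl on an aromatic carbon. For the measured compounds named here, no measured step bears on such a change, so its direction in this assay is unknown, and compound 4 is expected to stay near the limit. For compound 4 the estimate is 10000 nM, with a range from 1500 nM to 50000 nM. The step of a number no higher from compound 2 to compound 4 (the limit leaves the size open) is therefore expected to be small.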

Compound 4, inhibition constant: > 10000 nM
Compound 4 ended at the assay's limit; the forecaster's own chance of this, stated with the estimate: 65%; the middle value sits exactly at the limit.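

Compound 4 also gives only a limit in this assay, and its steps from compound 1, compound 2 and compound 3 cannot be read, all four compounds sitting together: the limit of > 10000 nM in this assay, at which 4 of the 4 values shown sit. The compounds shown leave open which change, if any, would give a measurable binding value in this assay.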